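Swapping the Bicyclic Amide Head on a Shared Core

The compounds below may be only part of what the source reports. "The series", "measured", "known", "first", "only" and "open" are said of these compounds alone.

Going by the values given here, compound 1 `O=C(NCc1ccc(S(=O)(=O)c2ccccc2)cc1)c1cc2ccncc2s1` stands highest of the two numbers so far measured in an ADME assay on microsomes from liver (Homo sapiens) for metabolic stability, read by LC-MS, with a stated time of 30 min, tested at 1 uM (a lower number here means that less of the compound is left, a higher number that more of the compound is left), where compound 1 gives 48%. Its nearest neighbour is compound 2 `O=C(NCc1ccc(S(=O)(=O)c2cccc(C(F)(F)F)c2)cc1)c1cc2ccncc2s1`, which in this assay gives 43%; the step of a number 5 percentage points lower from compound 1 to compound 2 (within the scatter) came with trifluoromethyl in place of hydrogen on an aromatic carbon and stays within the scatter. Compound 3 `O=C(NCc1ccc(S(=O)(=O)c2ccccc2)cc1)c1cnc2nccn2c1` differs from compound 1 elsewhere: a group of 9 heavy atoms (6 carbon, 3 nitrogen; one five-membered aromatic ring with 2 hetero atoms, one six-membered aromatic ring with 2 hetero atoms) in place of a group of 9 heavy atoms (7 carbon, 1 nitrogen, 1 sulfur; one five-membered aromatic ring with 1 hetero atom, one six-membered aromatic ring with 1 hetero atom), on a carbonyl carbon. Among the compounds with values here, the only measured step concerns a different part of the molecule and so bears little on an exchange at the carbonyl carbon; it shows merely that one small edit to this core moved nothing beyond the scatter. Without a step that tracks this exchange, compound 3 is expected to land near compound 1, a step of a number 2 percentage points higher from compound 1 to compound 3 (within the scatter) in this assay. The estimated value for compound 3 is 50%, with a range from 25% to 75%.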

Compound 3, percent of the compound remaining: 60%
The estimate for compound 3 lay 10 percentage points below the measured number; the range from low to high includes it.
By their numbers in this assay, from the lowest: compounds 2 and 1 (each within the scatter of the next); then compound 3.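

At the carbonyl carbon, the exchange of one group for the other gave a number 12 percentage points higher from compound 1 to compound 3 (beyond the scatter) in this assay, so this position, unlike the trifluoromethyl edit on the shared core, can move the read-out past the scatter. The two groups match in heavy atom count and ring sizes, yet the entering one holds 3 nitrogen and no sulfur and has 3 hydrogen-bond acceptors against 2, so a change of atoms alone, at unchanged size, sufficed here. Nothing available says which of these differences accounts for the step.

The compounds shown leave open whether the step follows the loss of sulfur or the gain of nitrogen, and how a single ring such as phenyl or pyridine would fare on that carbonyl carbon. From the compounds shown here alone, whether trifluoromethyl on the core of compound 3 stays as harmless as it did on compound 1 also remains open.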